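The compounds below may be only part of what the source reports. "The series", "measured", "known", "first", "only" and "open" are said of these compounds alone.

The measured compounds:

Compound 1, `COc1cc(Cl)nc(NC(=S)NC(=O)c2c(-c3ccc(Cl)cc3Cl)noc2C)n1`, gives 30.7%.
Compound 2, `COc1cc(OC)n2s/c(=N\C(=O)c3c(-c4ccc(Cl)cc4Cl)noc3C)nc2n1`, gives 49.3%.
Compound 3, `COc1cc(OC)nc(NC(=S)NC(=O)c2c(-c3ccc(Cl)cc3Cl)noc2C)n1`, gives 35.2%.

All three were examined in a functional assay on the whole organism for inhibition, with Brassica napus as the target, with a stated time of 72 h, tested at 10 mg/L; on this read-out higher numbers stand for more inhibition of growth at the one concentration tested and lower numbers for less inhibition of growth. Compound 3 and compound 1 share a core and differ in one place: chloro in place of methoxy on an aromatic carbon. This change produced a number 4.5 percentage points lower from compound 3 to compound 1 (within the scatter), so the two values cannot be told apart. Compound 2 carries a different core from compound 3; the difference between the two cores is not broken down here. Compound 2 shows the highest number of the three, and both gaps, to compound 3 and to compound 1, are beyond the scatter.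

Compound 4, `COc1cc(Cl)nc2n/c(=N/C(=O)c3c(-c4ccc(Cl)cc4Cl)noc3C)sn12`, has not yet been measured in this assay. It stands to compound 2 as compound 1 stands to compound 3: chloro in place of methoxy on an aromatic carbon. The surroundings of the place are not identical, however. In compound 2 the six-membered ring is part of a fused or bridged system of two rings, and the carbon is meta to a fused ring and para to a fused ring, whereas in compound 3 the carbon is meta to a large group. The change is therefore the same kind of change, not the same one.

A step of similar size is expected from compound 2 to compound 4, estimated as a number 4.3 percentage points lower from compound 2 to compound 4 (within the scatter) because a number 4.5 percentage points lower from compound 3 to compound 1 (within the scatter). Compound 4 is thus expected to give 45%. Its range is estimated to run from 30% to 60%.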

Compound 4, percent growth inhibition at one concentration: 28.6%
Estimate against measurement, compound 4: 16.4 percentage points above; measured number below the stated range.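

In this assay, chloro in place of methoxy on an aromatic carbon did not carry over unchanged from one core to the other: the new step is a number 20.7 percentage points lower from compound 2 to compound 4 (beyond the scatter). Set beside the earlier step, this shows that the same kind of change gave steps of different size on the two cores, so the step on the core of compound 3 could not be carried over as it stood to the core of compound 2: the same change on two cores in this assay, a number 4.5 percentage points lower (within the scatter) from compound 3 to compound 1 and a number 20.7 percentage points lower (beyond the scatter) from compound 2 to compound 4, 16.2 percentage points apart, beyond the scatter of two such steps. The comparison rests on a single pair on each core, read at one concentration, so it shows that the size of this step depended on the core in these four compounds, but it does not show why, nor what the same change would do on any further core.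

The compounds shown leave open whether another group at this place, such as an amine, an ethoxy group or a fluoro group, would also give steps that differ between the two cores. They also leave open whether the difference between the two steps would remain at other concentrations in this whole-organism test.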